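Swapping diethylamino for dimethylamino: half-life of compound 4

A few compounds are considered here, and "the series" means these few. Any claim that something is new, unique, unknown or untested is made for them only; others in the source may bear on it.

Measured in an ADME assay for pharmacokinetics, read by LC-MS, in phosphate buffer, with a stated time of 120 min, at pH 7.4, tested at 1 uM, in the presence of a further agent that is not named here; on this read-out higher numbers stand for a longer-lived compound and lower numbers for a shorter-lived compound:
- compound 1 `C=C(Cc1ccccc1)C(=O)Nc1ccccc1`: > 8.53 h
- compound 2 `C=C(Cl)C(=O)Nc1ccccc1`: 0.05 h
- compound 3 `CCN(CC)C/C=C/C(=O)Nc1ccccc1`: 2.83 h

Compound 1 gives > 8.53 h, which is a limit of the assay and not a number. For the measured compounds named here, only two of the three compounds therefore have actual numbers to compare. Of these, compound 3 stands highest at 2.83 h. Its nearest neighbour, compound 2, gives a much lower 0.05 h, a gap well beyond the scatter.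

The next compound to be measured is compound 4 `CN(C)C/C=C/C(=O)Nc1ccccc1`. It has dimethylamino in place of diethylamino on a saturated chain carbon bound to a double-bonded chain carbon. Going by the values given here, no pair of measured compounds shows a step of this kind, so any expectation in this assay must rest on compound 3 alone, at 2.83 h. The swap leaves the rest of that structure untouched, and no step beyond the scatter is expected. The expected change, a 1.3-fold lower number from compound 3 to compound 4 (0.11 log units; within the scatter), is a small one toward a shorter half-life and is estimated to lie within the scatter. For compound 4 the half-life is estimated at 2.2 h, with an expected range from 1 h to 5 h.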

Compound 4, half-life: 1.93 h
For compound 4 the middle estimate is 1.1-fold (0.06 log units) above the measured one; the range from low to high includes it.
By their numbers in this assay, from the lowest: compound 2; then compounds 4 and 3 (each within the scatter of the next). At a limit, above all of these: compound 1.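

For the compounds shown here, this is the first step at this position in this assay: exchanging the one amine for the other gives a 1.5-fold lower number from compound 3 to compound 4 (0.17 log units; within the scatter). The earlier compounds shown here offered no such pair, and this one shows that the half-life does not separate these two amines, even though diethylamino has 5 heavy atoms and dimethylamino has 3, with the rest of the structure the same. Nothing available bears on the reason for this outcome.

The compounds shown leave open how a ring amine such as piperidine or morpholine, an unsubstituted amino group, or a longer chain on the nitrogen, as in dipropylamino, would behave on this saturated chain carbon in this assay. Going by these compounds alone, they also leave open whether dimethylamino and diethylamino would remain indistinguishable on a different core, since this single pair is the only comparison of its kind and cannot establish a wider pattern.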